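This account rests on a few compounds, and the source may have more. Where it says the series, first, only, none or still open, it means among the compounds named here.

Measured in a functional assay on CEM-DNR-bulk cells (Homo sapiens), read by MTT assay, with a stated time of 72 h; a lower number here means a stronger inhibitor, a higher number a weaker inhibitor:
Compound 1 `Nc1nc(N)c2c(-c3cc4ccccc4o3)cn([C@@H]3O[C@H](CO)[C@@H](O)[C@H]3O)c2n1`: > 20000 nM
Compound 2 `Cc1nc(N)c2c(-c3ccsc3)cn([C@@H]3O[C@H](CO)[C@@H](O)[C@H]3O)c2n1`: > 20000 nM

In this assay compound 2 gives > 20000 nM, which is a limit of the assay and not a number. Going by the values given here, compound 1 also gives only a limit, > 20000 nM, so the series so far reads (the limit of > 20000 nM in this assay, at which 2 of the 2 values shown sit). Compound 3 `Cc1nc(N)c2c(-c3cc4ccccc4o3)cn([C@@H]3O[C@H](CO)[C@@H](O)[C@H]3O)c2n1` follows from compound 2 by one change: 1-benzofuran-2-yl in place of thiophen-3-yl on an aromatic carbon. Compound 1 already carries 1-benzofuran-2-yl and gives > 20000 nM, again a limit. No change beyond the scatter is expected in this assay, so the expected step is a number no higher from compound 2 to compound 3 (the limit leaves the size open). Compound 3 is estimated at 20000 nM, with an expected range of 8000 nM to 40000 nM.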

Compound 3, half-maximal inhibitory concentration: 6310 nM
Compound 3: middle estimate off by 3.2-fold (0.50 log units), on the high side; measured number below the stated range.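

In this assay, 1-benzofuran-2-yl in place of thiophen-3-yl on an aromatic carbon gives an at least 3.1-fold lower number from compound 2 to compound 3 (0.50 log units; beyond the scatter), so this position can move the read-out when methyl is present. With 1-benzofuran-2-yl held, methyl in place of amino gives an at least 3.1-fold lower number from compound 1 to compound 3 (0.50 log units; beyond the scatter), so among these compounds 1-benzofuran-2-yl alone does not bring the value off the limit. Compound 3 alone gives a number, and the other values remain limits: the limit of > 20000 nM in this assay, at which 2 of the 3 values shown sit.

From the compounds shown here alone, the full size of both steps stays open. Also open, going by these compounds, is how a phenyl group at this position, or a chlorine atom in place of methyl, would read.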